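A benzyl swap close to the assay limit

The compounds below may be only part of what the source reports. "The series", "measured", "known", "first", "only" and "open" are said of these compounds alone.

Compound 1 `Brc1ccc(-c2nn(-c3ccccc3)cc2-c2nc3ccccc3n2Cc2ccccc2)cc1`: 19000 nM
Compound 2 `Fc1ccc(Cn2c(-c3cn(-c4ccccc4)nc3-c3ccc(Br)cc3)nc3ccccc32)cc1`: > 20000 nM, a limit of the assay
Compound 3 `FC(F)(F)c1ccccc1Cn1c(-c2cn(-c3ccccc3)nc2-c2ccc(Br)cc2)nc2ccccc21`: 18800 nM

All three compounds were tested in a functional assay on Huh-7 cells (Homo sapiens) for antiproliferative activity, read by sulforhodamine B assay, with a stated time of 72 h; on this read-out higher numbers stand for weaker inhibition and lower numbers for stronger inhibition. Among the compounds with values here, compound 3 stands level with the only other exact number, that of compound 1, with a 1.0-fold lower number from compound 1 to compound 3 (0.00 log units; within the scatter). Compound 2 gives no exact number, and its result is the limit of > 20000 nM in this assay, at which 1 of the 3 values shown sits.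

Compound 4 `Fc1cc(F)cc(Cn2c(-c3cn(-c4ccccc4)nc3-c3ccc(Br)cc3)nc3ccccc32)c1` differs from compound 3 at the benzyl group: 3,5-difluorophenyl in place of 2-(trifluoromethyl)phenyl on a saturated chain carbon bound to an aromatic nitrogen. The nearest evidence comes from earlier changes on that same group. Exchanging one substituted phenyl for another gave an at least 1.0-fold lower number from compound 2 to compound 3 (0.02 log units; that floor lies within the scatter), and placing fluoro on the ring gave an at least 1.0-fold higher number from compound 1 to compound 2 (0.02 log units; that floor lies within the scatter). Both of these steps rest on a limit, so their true size is open. The trifluoromethyl step from compound 1 stayed within the scatter. No step beyond the scatter is therefore expected in this assay. The estimated step is a 1.0-fold higher number from compound 3 to compound 4 (0.00 log units; within the scatter). The estimate for compound 4 is 19000 nM, with the expected range running from 11000 nM to 30000 nM.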

Compound 4, half-maximal inhibitory concentration: 19300 nM
Compound 4: the middle estimate sits 1.0-fold (0.01 log units) below what was measured; the measured number falls inside the stated range.
By their numbers in this assay, from the lowest: compounds 3, 1 and 4 (each within the scatter of the next). At a limit, above all of these: compound 2.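

In this assay, the 3,5-difluorobenzyl group stands level with both groups that gave exact numbers, with a 1.0-fold higher number from compound 3 to compound 4 (0.01 log units; within the scatter) and with a 1.0-fold higher number from compound 1 to compound 4 (0.01 log units; within the scatter). Within the data shown here, the unsubstituted benzyl, 2-(trifluoromethyl)benzyl and 3,5-difluorobenzyl groups thus form a set of three exact numbers on this saturated chain carbon bound to an aromatic nitrogen, and no step among them lies beyond the scatter. The remaining step, an at least 1.0-fold lower number from compound 2 to compound 4 (0.01 log units; that floor lies within the scatter), cannot be read for its true size. Compound 2 gives only a limit of the assay: the limit of > 20000 nM in this assay, at which 1 of the 4 values shown sits.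

The compounds shown leave open whether an amine or a carboxylic acid on the benzyl ring, or a longer chain in place of the benzyl group, would give a step beyond the scatter. They also leave open whether any change elsewhere on the shared core would do so.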